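Isopropylamino added to the methyl of compound 1

The source may report more compounds than this note shows. Statements on the series, on what has been measured and on what is new or still open speak of the compounds shown alone.

Compound 1 `Cc1nc(NC(C)C)c2cnn(-c3ccccc3)c2n1` gives > 100000 nM in a functional assay on G-361 cells (Homo sapiens) for cytotoxicity, read by sulforhodamine B assay (a higher number here means that more compound is tolerated, a lower number that less compound is tolerated), which is a limit of the assay and not a number. Compound 2 `Cc1nc(NCc2ccccc2)c2cnn(-c3ccccc3)c2n1` gives > 100000 nM in this assay, likewise a limit. Compound 3 `CCNc1nc(C)nc2c1cnn2-c1ccccc1` gives > 100000 nM in this assay, again a limit. The steps among these three read a step that the two limits leave unreadable from compound 1 to compound 2, a step that the two limits leave unreadable from compound 1 to compound 3 and a step that the two limits leave unreadable from compound 2 to compound 3, so no size or direction can be taken from any of them; all three values share one position, (the limit of > 100000 nM in this assay, at which 3 of the 3 values shown sit).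

Compound 4 `CC(C)NCc1nc(NC(C)C)c2cnn(-c3ccccc3)c2n1` differs from compound 1 by isopropylamino in place of hydrogen on a saturated chain carbon bound to an aromatic carbon. Among the compounds with values here, none of the measured steps touches this position, and none of them carries a readable size, so they give no expected direction for this change. Because all three measured values sit at the limit of > 100000 nM in this assay, at which 3 of the 3 values shown sit, the step expected from compound 1 to compound 4 is a step that the limit leaves unreadable from compound 1 to compound 4, most likely again reported only as a limit in this assay. Compound 4 is therefore estimated at 150000 nM in this assay, within a range of 40000 nM to 500000 nM.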

Compound 4, concentration lethal to 50% of the cells: > 100000 nM
Compound 4 gave a limit, no number; the forecaster's own chance of this, stated with the estimate: 80%; the middle value lies beyond the limit too.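

Compound 1 and compound 4 both stand only as limits in this assay, so the step between them cannot be read: the limit of > 100000 nM in this assay, at which 4 of the 4 values shown sit.

The compounds shown leave open whether any change to the shared core gives a readable value in this assay.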